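Replacing 2-fluoro-4-(trifluoromethyl)phenyl with 4-hydroxyphenyl in compound 2

A few compounds are considered here, and "the series" means these few. Any claim that something is new, unique, unknown or untested is made for them only; others in the source may bear on it.

Compound 1 `N#Cc1ccc(/C=C/S(=O)(=O)Cc2ccc(Nc3ncnc4ccccc34)cc2)cc1`: > 100000 nM (a limit)
Compound 2 `O=S(=O)(/C=C/c1ccc(C(F)(F)F)cc1F)Cc1ccc(Nc2ncnc3ccccc23)cc1`: 100000 nM
Compound 3 `O=S(=O)(/C=C/c1ccc(O)cc1)Cc1ccc(Nc2ncnc3ccccc23)cc1`: not yet measured

For the measured compounds named here, in a functional assay on U-251 cells (Homo sapiens) (on this read-out higher numbers stand for weaker inhibition of growth and lower numbers for stronger inhibition of growth), compound 2 gives 100000 nM, the only actual number so far. Compound 1 gives > 100000 nM, which is a limit of the assay. Going by the values given here, the single measured step is a number no higher from compound 1 to compound 2 (the limit leaves the size open), and it changes the same place as the step now in question. The new change is 4-hydroxyphenyl in place of 2-fluoro-4-(trifluoromethyl)phenyl on a double-bonded chain carbon bound to a double-bonded chain carbon. The measured step gives no size to carry over, so only a modest move in this assay towards lower numbers is expected, because compound 2 gives 100000 nM and sits at the edge of the limit of > 100000 nM in this assay, at which 1 of the 2 values shown sits. The estimated step is a 1.7-fold lower number from compound 2 to compound 3 (0.22 log units; within the scatter). For compound 3 the expected value is 60000 nM, with an estimated range of 20000 nM to 100000 nM.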

Compound 3, concentration for 50% growth inhibition: 300 nM
The estimate for compound 3 lay 200-fold (2.30 log units) above the measured number, and the stated range ends above it.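

The earlier pair left this position looking flat, but it can carry a very large move in this assay: 4-hydroxyphenyl in place of 2-fluoro-4-(trifluoromethyl)phenyl gives a 330-fold lower number from compound 2 to compound 3 (2.52 log units; beyond the scatter). Hydroxy in place of cyano on an aromatic carbon gives an at least 330-fold lower number from compound 1 to compound 3 (2.52 log units; beyond the scatter). The size of that second step is only a lower bound, resting on a limit of the assay: the limit of > 100000 nM in this assay, at which 1 of the 3 values shown sits.

The step from compound 2 to compound 3 swaps whole groups, so it cannot separate what the hydroxy brings from what the loss of the fluorine and the trifluoromethyl brings. It also leaves open whether another group on the same aromatic carbon, such as an amine, a methoxy or a carboxylic acid, would keep the number this low.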